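This account rests on a few compounds, and the source may have more. Where it says the series, first, only, none or still open, it means among the compounds named here.

Measured in a functional assay on Jurkat cells (Homo sapiens) for cytotoxicity; a lower number here means a stronger inhibitor, a higher number a weaker inhibitor:
- Compound 1 `CCCC/C=C/C1=C(CO)[C@H](O)[C@H]2O[C@H]2C1=O`: 15000 nM
- Compound 2 `C/C=C/C1=C(CO)[C@H](O)[C@H]2O[C@H]2C1=O`: > 80000 nM
- Compound 3 `C=CC1=C(CO)[C@H](O)[C@H]2O[C@H]2C1=O`: > 80000 nM

Compound 2 gives > 80000 nM, which is a limit of the assay and not a number; it sits at the limit of > 80000 nM in this assay, at which 2 of the 3 values shown sit. Compound 3 gives > 80000 nM, which is also a limit.

Compound 4 `O=C1C(/C=C/c2ccccc2)=C(CO)[C@H](O)[C@H]2O[C@@H]12` changes compound 2 in one place: phenyl in place of methyl on a double-bonded chain carbon bound to a double-bonded chain carbon. In words, this puts phenyl in place of methyl on a double-bonded chain carbon bound to a double-bonded chain carbon.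

For the measured compounds named here, no measured step tests a phenyl group, so the guidance is indirect. The most useful step is an at least 5.3-fold higher number from compound 1 to compound 2 (0.72 log units; beyond the scatter), in which propyl is lost and the number rises. The other step, a step that the two limits leave unreadable from compound 2 to compound 3, gives no readable size.

Compound 4 gains carbon on the chain, so, going by the step from compound 1, a modest move to a lower number is expected, though it may not appear. The expected change is an at least 3.2-fold lower number from compound 2 to compound 4 (0.50 log units; beyond the scatter). Compound 4 is estimated at 25000 nM, with an expected range from 8000 nM to 80000 nM.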

Compound 4, half-maximal inhibitory concentration: 20000 nM
Beside the measured number, compound 4's estimate is 1.3-fold (0.10 log units) above it; low and high end bracket the measured number.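

In this assay, for the compounds shown here, the step of an at least 4.0-fold lower number from compound 2 to compound 4 (0.60 log units; beyond the scatter) shows that this position on the chain tolerates an aromatic ring: phenyl in place of methyl goes with a lower number, which the earlier compounds, with only open chains here, could not show. Set against the butyl group, the step of a 1.3-fold higher number from compound 1 to compound 4 (0.12 log units; within the scatter) shows that phenyl and butyl cannot be told apart at this position, so a lower number here does not depend on the group being a saturated chain. The first step gives only a minimum size because compound 2 has a limit and not a number: the limit of > 80000 nM in this assay, at which 2 of the 4 values shown sit.

As far as these compounds go, whether a longer chain, such as octyl, would go further remains open. So does whether a phenyl ring carrying an amine or a carboxylic acid would shift the number in either direction.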